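Three limits and one methyl step in a small series

The compounds below may be only part of what the source reports. "The series", "measured", "known", "first", "only" and "open" are said of these compounds alone.

Compound 3 `Cc1ncc2cnnc(O)n12` is the smallest member of the set. In a functional assay for inhibition, with Homo sapiens as the target (a higher number here means a weaker inhibitor, a lower number a stronger inhibitor), compound 3 gives > 48000 nM, which is a limit of the assay and not a number. Compound 1 `Cc1nc(Cc2ccccc2)n2c(O)nncc12` carries a benzyl group and a hydroxyl on the shared core; in this assay compound 1 gives > 48000 nM, again a limit. Compound 2 `Cc1nc(C)n2c(S)nncc12` carries two methyl groups and a thiol; in this assay compound 2 gives > 48000 nM, also a limit. Where compound 3 stands is thus given only by the limit of > 48000 nM in this assay, at which 3 of the 3 values shown sit: no member of the set has yielded a measured number, and no order among the three can be drawn.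

Compound 4 `Cc1nc(C)n2c(O)nncc12` is not yet measured. It differs from compound 3 by methyl in place of hydrogen on an aromatic carbon. Within the data shown here, no measured pair in the set shares this change, so no size for such a step is on record. Among the measured compounds shown here, the step that the limit leaves unreadable from compound 3 to compound 4 is expected to be none beyond the scatter, since every value so far sits at the same limit. Compound 4 is estimated at 60000 nM in this assay, with a range from 20000 nM to 200000 nM, and the assay is expected most likely to report only a limit again.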

Compound 4, half-maximal inhibitory concentration: > 48000 nM
Compound 4 was reported as a limit; the forecaster's own chance of this, stated with the estimate: 85%; the middle value lies beyond the limit too.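

No step from compound 1, compound 2 or compound 3 to compound 4 can be read in this assay, because each pair ends in the same limit: the limit of > 48000 nM in this assay, at which 4 of the 4 values shown sit.

The compounds shown leave open how these four rank in this assay and what size the methyl, hydroxy and phenyl changes have.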